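A few compounds are considered here, and "the series" means these few. Any claim that something is new, unique, unknown or untested is made for them only; others in the source may bear on it.

Series notes. Compound 3 `C#Cc1ccnc(O[C@@H]2CC[C@@H](C)N(C(=O)c3ccccc3-n3nccn3)C2)c1` is measured in a functional assay on CHO-K1 cells for antagonist activity at Orexin receptor type 2 (Homo sapiens), read by FLIPR and calcium flux (on this read-out higher numbers stand for weaker inhibition and lower numbers for stronger inhibition), at 10 nM, the lowest of three numbers; compound 2 `CCc1ccnc(O[C@@H]2CC[C@@H](C)N(C(=O)c3ccccc3-n3nccn3)C2)c1` stands nearest at 11 nM, a gap within the scatter, and compound 1 `CC(C)OC(=O)c1ccccc1C(=O)N1C[C@H](Oc2cc(C#N)ccn2)CC[C@H]1C` furthest at 38 nM, a gap beyond it. Compound 4 `COC(=O)c1ccnc(O[C@@H]2CC[C@@H](C)N(C(=O)c3ccccc3-n3nccn3)C2)c1` differs from compound 3 by methoxycarbonyl in place of ethynyl on an aromatic carbon. For the measured compounds named here, the only single-point step at this carbon is a 1.1-fold lower number from compound 2 to compound 3 (0.04 log units; within the scatter), so exchanging the group there has so far left this assay unmoved; methoxycarbonyl, however, brings hydrogen-bond acceptors that ethynyl lacks, and no measured step covers that. Going by the values given here, compound 1 differs from compound 3 in more than one place, so its number gives no step. Compound 4 is expected at 25 nM, with a range from 8 nM to 80 nM. The expected step is therefore a 2.5-fold higher number from compound 3 to compound 4 (0.40 log units; beyond the scatter), a modest weakening.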

Compound 4, half-maximal inhibitory concentration: 22 nM
Compound 4: middle estimate off by 1.1-fold (0.06 log units), on the high side; the measured number falls inside the stated range.
By their numbers in this assay, from the lowest: compounds 3, 2, 4 and 1 (each within the scatter of the next, the first and the last beyond it).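

In this assay, this carbon opposite the ring nitrogen now gives a change that clears the scatter, a 2.2-fold higher number from compound 3 to compound 4 (0.34 log units; beyond the scatter), against ethynyl, while the comparison with ethyl, a 2.0-fold higher number from compound 2 to compound 4 (0.30 log units; within the scatter), stays within it. Methoxycarbonyl brings hydrogen-bond acceptors to this carbon, and the number shifts only modestly, so the position accepts a larger group with acceptors. No measured evidence bears on the origin of this shift. Still open, from the compounds shown here alone, is how a carboxylic acid, an amine or a longer chain at this carbon would read, and whether any group here would fall clearly below the numbers of ethyl and ethynyl.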